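From benzyl to acetyl on a ring amine

The compounds below may be only part of what the source reports. "The series", "measured", "known", "first", "only" and "open" are said of these compounds alone.

In a physicochemical assay for solubility, with a stated time of 3 days, at pH 2 (a higher number here means a more soluble compound, a lower number a less soluble compound), compound 2 `NC(=O)c1ccc2[nH]c(-c3ccc(OCCC4CCCCN4Cc4ccccc4)cc3)nc2c1` gives > 400000 nM, which is a limit of the assay and not a number. Two relatives offer no number either: compound 1 `NC(=O)c1ccc2[nH]c(-c3ccc(OCC4CCCN(Cc5ccc(Cl)c(Cl)c5)C4)cc3)nc2c1` has "not determined" (no result reported), and compound 3 `NC(=O)c1ccc2[nH]c(-c3ccc(OCC4CCN(C(=O)c5ccccc5)CC4)cc3)nc2c1` has "not determined" (no result reported). The next compound, compound 4 `CC(=O)N1CCCCC1CCOc1ccc(-c2nc3cc(C(N)=O)ccc3[nH]2)cc1`, has acetyl in place of benzyl on an amine nitrogen in a ring. Within the data shown here, no measured pair of compounds shows what this change does, so any forecast here is loose. A fall beyond the usual scatter seems the likelier outcome, and the expected step is an at least 4.0-fold lower number from compound 2 to compound 4 (0.60 log units; beyond the scatter). For compound 4, the estimated result in this assay is 100000 nM, with an expected range of 10000 nM to 400000 nM.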

Compound 4, solubility: > 400000 nM
Compound 4 ended at the assay's limit (the forecaster's own chance of this, stated with the estimate: 35%); middle value at least 4.0-fold (0.60 log units) from the limit.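

In this assay compound 2 and compound 4 both stop at a limit of the assay and not at a number, and no step can be read between them. On these data alone, whether acetyl in place of benzyl on an amine nitrogen in a ring changes the result at all stays open.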